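Nitro for methoxy on the amide aryl: compound 4

The compounds below may be only part of what the source reports. "The series", "measured", "known", "first", "only" and "open" are said of these compounds alone.

Measured compounds:
compound 1 `COc1ccc(C(=O)Nc2nc3c(OC)cccc3s2)cc1` gives 2.11 ug/mL in a functional assay on SK-HEP1 cells (Homo sapiens) for antiproliferative activity, read by sulforhodamine B assay; on this read-out higher numbers stand for weaker inhibition of growth and lower numbers for stronger inhibition of growth.
compound 2 `COc1ccc(C(=O)Nc2nc3cc(OC)ccc3s2)cc1` reaches only the assay limit > 10 ug/mL.
compound 3 `COc1cccc2sc(NC(=O)c3ccc([N+](=O)[O-])cc3)nc12` reaches only the assay limit > 10 ug/mL.

Compounds 1 and 2 have the same atoms joined differently; how the two cores differ is not broken down here. From compound 1 to compound 3 the change nitro in place of methoxy on an aromatic carbon gave an at least 4.7-fold higher number from compound 1 to compound 3 (0.67 log units; beyond the scatter). Compound 4 `COc1ccc2sc(NC(=O)c3ccc([N+](=O)[O-])cc3)nc2c1` carries the same change on the core of compound 2, (nitro in place of methoxy on an aromatic carbon), with the place described in the same words. Compound 2 already sits at the limit of > 10 ug/mL in this assay, at which 2 of the 3 values shown sit, so the step is expected to be small, a step that the limit leaves unreadable from compound 2 to compound 4. Compound 4 is expected to sit at the limit again, with an estimate of 20 ug/mL in this assay , between 6 ug/mL and 60 ug/mL.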

Compound 4, concentration for 50% growth inhibition: > 10 ug/mL
Compound 4: a limit, no number; the forecaster's own chance of this, stated with the estimate: 85%; the middle value does not contradict the limit.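

In this assay, within the data shown here, compound 4 gives > 10 ug/mL, a limit and not a number, and compound 2 is also only a limit, so no step between them can be read. The compounds shown leave open whether nitro in place of methoxy changes growth inhibition on the core of compound 2.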